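Swapping Dimethylamino for Diethylamino on a Cinnamanilide Chain

The source may report more compounds than this note shows. Statements on the series, on what has been measured and on what is new or still open speak of the compounds shown alone.

Measured compounds:
compound 1 `COc1cc(/C=C/C(=O)Nc2ccccc2)ccc1OCCCN1CCCC1` gives 1.57
compound 2 `COc1cc(/C=C/C(=O)Nc2ccccc2)ccc1OCCCCN(C)C` gives 1.57

In a physicochemical assay for lipophilicity, using the shake flask method, measured as octanol-water partition, at pH 7.4 (on this read-out lower numbers stand for lower lipophilicity and higher numbers for higher lipophilicity), compound 2 stands level with compound 1 at the digits shown; the step of no change at the digits printed from compound 1 to compound 2 (within the scatter) is within the scatter. Compound 3 `CCN(CC)CCCCOc1ccc(/C=C/C(=O)Nc2ccccc2)cc1OC` is the next compound. It differs from compound 2 in this way: diethylamino in place of dimethylamino on a saturated chain carbon, four bonds along the chain from an oxygen on an aromatic ring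

Within the data shown here, only one measured step exists, from compound 1 to compound 2, and it exchanged one amine for another rather than lengthening the substituents on the nitrogen, so it bears on this change only loosely. It shows that the readout tolerated a rearrangement of the amine without movement. For compound 3 a rise beyond the scatter is expected, as the step of a number 0.73 log units higher from compound 2 to compound 3 (beyond the scatter) is estimated. Compound 3 is therefore expected to give 2.3, within a range from 1.7 to 2.9.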

Compound 3, partition coefficient: 1.59
For compound 3 the middle estimate is 0.71 log units above the measured one, and the stated range ends above it.
By their numbers in this assay, from the lowest: compounds 1, 2 and 3 (each within the scatter of the next).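

At this place, on a saturated chain carbon, four bonds along the chain from an oxygen on an aromatic ring, diethylamino in place of dimethylamino gives a number 0.02 log units higher from compound 2 to compound 3 (within the scatter) in this assay, so the read-out does not separate these two amines. The earlier step exchanged one amine for another, whereas this one lengthens the groups on the nitrogen, and it too stays level. The remaining pair gives a number 0.02 log units higher from compound 1 to compound 3 (within the scatter) in this assay, which places pyrrolidin-1-yl and the diethylamino compound level as well.

On these data alone, whether a morpholine or a piperidine at the end of the chain would also read level remains open. So does the effect of a carboxylic acid in place of the amine, or of a longer chain. No supporting measurement accounts for these level readings.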